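The source may report more compounds than this note shows. Statements on the series, on what has been measured and on what is new or still open speak of the compounds shown alone.

For the measured compounds named here, in a functional assay on HCT-116 cells (Homo sapiens) for antiproliferative activity, read by MTT assay, with a stated time of 72 h (a higher number here means a weaker inhibitor, a lower number a stronger inhibitor), two compounds sharing one core have numbers so far. Compound 1 (`Cc1cc(C)cc(OCCCON2C(N)=NC(N)=NC23CCOCC3)c1`) gives 190 nM, while compound 2 (`NC1=NC2(CCOCC2)N(OCCCOc2cc(Cl)c(Cl)cc2Cl)C(N)=N1`) gives 2750 nM, the higher of the two numbers and therefore the weaker inhibitor of this pair. Compound 3 (`NC1=NC2(CCOCC2)N(OCCCOc2cccc(Cl)c2)C(N)=N1`) differs from compound 2 by 3-chlorophenyl in place of 2,4,5-trichlorophenyl on an oxygen on a saturated carbon. Going by the values given here, one measured step bears on this change, as it falls at the same place: a 14-fold higher number from compound 1 to compound 2 (1.16 log units; beyond the scatter), a large step beyond the scatter, with 2,4,5-trichlorophenyl replacing 3,5-dimethylphenyl. It is a single pair and a thin guide. Compound 3 keeps one chlorine, so in this assay a moderate fall from compound 2 is expected, smaller than that step. The estimated change is a 3.7-fold lower number from compound 2 to compound 3 (0.56 log units; beyond the scatter). For compound 3 the expected value is 750 nM, with an estimated range of 220 nM to 2500 nM.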

Compound 3, half-maximal inhibitory concentration: 120 nM
For compound 3 the middle estimate is 6.3-fold (0.80 log units) above the measured one; measured number below the stated range.
By their numbers in this assay, from the lowest: compounds 3 and 1 (each within the scatter of the next); then compound 2.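

At the place on an oxygen on a saturated carbon, a chlorine on the ring does not by itself bring the high number of compound 2. In this assay the change to 3-chlorophenyl gives a 23-fold lower number from compound 2 to compound 3 (1.36 log units; beyond the scatter) and so removes the whole loss seen with 2,4,5-trichlorophenyl. Within this set, 3-chlorophenyl and 3,5-dimethylphenyl are not told apart, since the exchange gives a 1.6-fold lower number from compound 1 to compound 3 (0.20 log units; within the scatter) and only 2,4,5-trichlorophenyl stands away from the other two. Nothing given here offers a reason for this difference.

The compounds shown do not tell which of the three chlorines of compound 2 goes with the loss, nor how an unsubstituted phenyl or a dichlorophenyl would compare. As far as these compounds go, a ring bearing an amine or a carboxylic acid, and a longer chain to the oxygen, also remain open.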